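Swapping a substituted phenyl amide for a thiazole

This account rests on a few compounds, and the source may have more. Where it says the series, first, only, none or still open, it means among the compounds named here.

Two amides that share one core have been tested. Compound 1 `COc1ccc2nc(C)cc(OCC(=O)Nc3cc(C)cc(C)c3)c2c1` in a toxicity assay on HepG2 cells (Homo sapiens) for inhibition, read by CellTiter-Glo, with a stated time of 48 h (a higher number here means a weaker inhibitor, a lower number a stronger inhibitor), gives 20000 nM. Compound 2 `COc1ccc2nc(C)cc(OCC(=O)Nc3ccc(Cl)c(OC)c3)c2c1` reaches only a limit of this assay, > 100000 nM, so no exact number is known for it (the limit of > 100000 nM in this assay, at which 1 of the 2 values shown sits). Within the data shown here, the measured step of an at least 5.0-fold higher number from compound 1 to compound 2 (0.69 log units; beyond the scatter) is the only guide available. Compound 3 `COc1ccc2nc(C)cc(OCC(=O)Nc3nccs3)c2c1` differs from compound 2 by 1,3-thiazol-2-yl in place of 4-chloro-3-methoxyphenyl on an amide-type nitrogen. Among the measured compounds shown here, no measured step involves a thiazolyl group, so the direction stays open. A change of a number no higher from compound 2 to compound 3 (the limit leaves the size open) is expected. Compound 3 is estimated at 100000 nM in this assay, with a range from 20000 nM to 300000 nM.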

Compound 3, half-maximal inhibitory concentration: > 100000 nM
Compound 3: a limit, no number; the forecaster's own chance of this, stated with the estimate: 55%; the middle value sits exactly at the limit.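

In this assay, compound 3 gives a limit, not a number: the limit of > 100000 nM in this assay, at which 2 of the 3 values shown sit. The step between compound 2 and compound 3 cannot be read. Compared with the 3,5-dimethylphenyl group, 1,3-thiazol-2-yl on the amide-type nitrogen gives an at least 5.0-fold higher number from compound 1 to compound 3 (0.69 log units; beyond the scatter), so a five-membered aromatic ring with 2 hetero atoms also gives a weak reading here, and only compound 1 gives an exact number.

As far as these compounds go, it remains open whether a non-aromatic group on this nitrogen, such as a cyclohexyl ring or a chain ending in an amine, would bring a number back into range.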